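The source may report more compounds than this note shows. Statements on the series, on what has been measured and on what is new or still open speak of the compounds shown alone.

Within the data shown here, compound 3 `c1cc(CNC2CCN(CCCc3c[nH]c4ccc(-n5cnnc5)cc34)CC2)co1` gives 4.5 nM in an assay on CHO cells for displacement of a labelled ligand from 5-hydroxytryptamine receptor 1D (Homo sapiens) (on this read-out higher numbers stand for weaker inhibition and lower numbers for stronger inhibition), the highest of the three numbers measured so far. In this assay compound 1 `CN(Cc1ccccc1)CC1CCN(CCCc2c[nH]c3ccc(-n4cnnc4)cc23)CC1` gives 0.9 nM and compound 2 `C[C@@H](NCC1CCN(CCCc2c[nH]c3ccc(-n4cnnc4)cc23)CC1)c1ccccc1` gives 1.4 nM. Compound 4 `CN(Cc1cccs1)C1CCN(CCCc2c[nH]c3ccc(-n4cnnc4)cc23)CC1` differs from compound 3 in one place: methyl((thiophen-2-yl)methyl)amino in place of ((furan-3-yl)methyl)amino on a saturated ring carbon. Among the measured compounds shown here, two measured steps bear on this change: a 5.0-fold higher number from compound 1 to compound 3 (0.70 log units; beyond the scatter) and a 3.2-fold higher number from compound 2 to compound 3 (0.51 log units; beyond the scatter), each of which paired the loss of a methyl on the amine with a change of aryl group and raised the number. Compound 4 brings a methyl back onto that amine, so a return toward the lower numbers is expected, a 3.0-fold lower number from compound 3 to compound 4 (0.48 log units; beyond the scatter). Compound 4 is therefore estimated at 1.5 nM, with a range from 0.6 nM to 4 nM.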

Compound 4, half-maximal inhibitory concentration: 4.3 nM
Beside the measured number, compound 4's estimate is 2.9-fold (0.46 log units) below it, and the stated range ends below it.
By their numbers in this assay, from the lowest: compounds 1 and 2 (each within the scatter of the next); then compounds 4 and 3 (each within the scatter of the next).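

In this assay, methyl((thiophen-2-yl)methyl)amino on the saturated ring carbon gives a 1.0-fold lower number from compound 3 to compound 4 (0.02 log units; within the scatter), so this exchange of groups leaves the number unmoved. The two lowest numbers still belong to the compounds with a saturated chain carbon on that ring carbon, as a 3.1-fold higher number from compound 2 to compound 4 (0.49 log units; beyond the scatter) and a 4.8-fold higher number from compound 1 to compound 4 (0.68 log units; beyond the scatter) show. Nothing measured here accounts for this result.

Going by these compounds, the change joins a methyl on the amine to a change of ring, so their separate shares remain open. Benzyl(methyl)amino directly on the ring carbon, or methyl((furan-3-yl)methyl)amino there, would separate them.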